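Inverting one ring stereocentre in a melanocortin-4 binder

A few compounds are considered here, and "the series" means these few. Any claim that something is new, unique, unknown or untested is made for them only; others in the source may bear on it.

Of the compounds shown here, three sharing one core have been measured in an assay on HEK293 cells for displacement of a labelled ligand from Melanocortin receptor 4 (Homo sapiens); a lower number here means a stronger inhibitor, a higher number a weaker inhibitor. For the measured compounds named here, compound 1 `CCOC(=O)N1CC[C@H](c2ccc(Cl)cc2)[C@H]1C(=O)N1CCN(c2ccc(C)cc2[C@@H](N)C(C)C)CC1` gives 42 nM, and compound 2 `Cc1ccc(N2CCN(C(=O)[C@@H]3[C@@H](c4ccc(Cl)cc4)CCN3C(=O)OC(C)C)CC2)c([C@@H](N)C(C)C)c1` gives 68 nM; the only single-point step among them, a 1.6-fold higher number from compound 1 to compound 2 (0.21 log units; within the scatter), is small. Compound 3 `Cc1ccc(N2CCN(C(=O)[C@H]3[C@@H](c4ccc(Cl)cc4)CCN3C(=O)C(C)(C)C)CC2)c([C@@H](N)C(C)C)c1` gives 7.2 nM, the lowest of the three numbers, beyond the scatter from both others, so it stands as the strongest binder here.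

Compound 4 `Cc1ccc(N2CCN(C(=O)[C@@H]3[C@@H](c4ccc(Cl)cc4)CCN3C(=O)C(C)(C)C)CC2)c([C@@H](N)C(C)C)c1` keeps every atom and bond of compound 3 and changes only configuration: the two compounds have the same atoms and bonds and differ only in configuration as drawn: 1 of 3 stereo elements differ; a stereocentre at a saturated ring carbon is drawn R in compound 3 and S in compound 4. Going by the values given here, no measured step involves a change in configuration, so none bears directly on this move; the one measured step concerns a methyl and was within the scatter. Among the compounds with values here, compounds 1 and 2 differ from compound 4 in more than one place and show only that numbers higher than that of compound 3, beyond the scatter, occur within this set. A single stereocentre inversion is therefore expected to weaken binding, estimated as a 6.3-fold higher number from compound 3 to compound 4 (0.80 log units; beyond the scatter). Compound 4 is expected to give about 45 nM, within a range from 8 nM to 250 nM.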

Compound 4, inhibition constant: 79 nM
For compound 4 the middle estimate is 1.8-fold (0.24 log units) below the measured one; the measured number falls inside the stated range.
By their numbers in this assay, from the lowest: compound 3; then compounds 1, 2 and 4 (each within the scatter of the next).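

For the compounds shown here, until now no measured step had touched configuration, and this one does: in this assay, an 11-fold higher number from compound 3 to compound 4 (1.04 log units; beyond the scatter), a large change from inverting one saturated ring carbon. That change can be assigned to the stereocentre alone, because nothing else separates the pair: the fact that compounds 3 and 4 differ only in the configuration as drawn With the configuration of compound 4 in place, swapping the group on the carbonyl carbon registers only within the scatter, both as a 1.2-fold higher number from compound 2 to compound 4 (0.07 log units; within the scatter) and as a 1.9-fold higher number from compound 1 to compound 4 (0.27 log units; within the scatter), so the tert-butyl group gives a clear advantage only in compound 3.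

From the compounds shown here alone, whether the inversion would have a similar effect with ethoxy or isopropoxy on the carbonyl carbon remains open. So does how an amine or a longer chain at that carbonyl carbon would behave in either configuration.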